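One Added Methyl on the Ester Side of Compound 2

The source may report more compounds than this note shows. Statements on the series, on what has been measured and on what is new or still open speak of the compounds shown alone.

- Compound 1 `COC(=O)N(C)CC#CCn1ccnc1`: > 100 mg/kg (a limit)
- Compound 2 `COC(=O)N(C)CC#CCn1cncc1C`: 5.4 mg/kg
- Compound 3 `CCOC(=O)N(C)CC#CCn1cncc1C`: not yet measured

In a functional assay on the whole organism for antagonist activity, with Mus musculus as the target (on this read-out higher numbers stand for an effect only at larger amounts of compound and lower numbers for an effect already at smaller amounts), compound 1 reaches only a limit, > 100 mg/kg. For the measured compounds named here, compound 2, at 5.4 mg/kg, holds the only true number so far. The change to compound 3 is methyl in place of hydrogen on a saturated chain carbon bound to an oxygen next to a carbonyl group, which turns methoxy into ethoxy. Going by the values given here, the one measured step, an at least 18-fold lower number from compound 1 to compound 2 (1.26 log units; beyond the scatter), also adds a methyl, but on an aromatic carbon, so it offers only a loose guide to this different place. A modest move towards a higher number is expected, an estimated 2.2-fold higher number from compound 2 to compound 3 (0.35 log units; beyond the scatter). The estimate for compound 3 is 12 mg/kg, with an expected range of 4 mg/kg to 40 mg/kg.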

Compound 3, dose for half-maximal effect: 66 mg/kg
Compound 3: the middle estimate sits 5.5-fold (0.74 log units) below what was measured; measured number outside the range, above it.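

The ester side tolerates little change: in this assay, swapping methoxy for ethoxy gives a 12-fold higher number from compound 2 to compound 3 (1.09 log units; beyond the scatter). A single added methyl therefore matters as much here as on the aromatic carbon, but it pulls the other way, since that earlier change gave an at least 18-fold lower number from compound 1 to compound 2 (1.26 log units; beyond the scatter). Only compound 1 sits at a limit, and compound 3 keeps a true number: the limit of > 100 mg/kg in this assay, at which 1 of the 3 values shown sits.

On these data alone, whether a longer chain such as propoxy would raise the number further remains open, as does the effect of a branched isopropoxy group. The compounds shown also cannot say why this one methyl has so large an effect.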